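The source may hold more compounds than are shown below. What is called first, only, known or untested is meant among the compounds shown, and "the series" means these compounds.

Of the compounds shown here, two built on the same core have been tested in a functional assay on MDA-MB-231 cells (Homo sapiens) for antiproliferative activity, read by MTT assay, with a stated time of 72 h; a lower number here means a stronger inhibitor, a higher number a weaker inhibitor. Compound 1 `CC1=CC[C@H]2[C@H](CC[C@]2(C)O)C(C)(C)[C@@H]1CC[C@H]1[C@]2(C)CC[C@H](OC(=O)CCC(=O)O)C(C)(C)O[C@H]2CC[C@@]1(C)O` gives 27900 nM in this assay. Compound 2 `CC1=CC[C@H]2[C@H](CC[C@]2(C)O)C(C)(C)[C@@H]1CC[C@H]1[C@]2(C)CC/C(=N/OCc3ccccc3)C(C)(C)O[C@H]2CC[C@@]1(C)O` gives 38200 nM. Compound 1 has the lower of the two numbers, but the gap between them lies within the usual scatter, so neither can be called the stronger of the pair.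

Compound 3 `CC1=CC[C@H]2[C@H](CC[C@]2(C)O)C(C)(C)[C@@H]1CC[C@H]1[C@]2(C)CC[C@H](OC(=O)c3cccc([N+](=O)[O-])c3)C(C)(C)O[C@H]2CC[C@@]1(C)O` has not yet been measured. It differs from compound 1 in one place: 3-nitrophenyl in place of 2-carboxyethyl on a carbonyl carbon. Among the compounds with values here, no measured pair shows how a change of this kind moves the number in this assay. Because compound 1 sits at 27900 nM and compound 2 sits at 38200 nM, both weak, only a small step is expected, without a clear direction. The step from compound 1 to compound 3 is estimated as a 1.4-fold lower number from compound 1 to compound 3 (0.14 log units; within the scatter). Compound 3 is expected to give about 20000 nM, with a likely range from 6000 nM to 70000 nM.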

Compound 3, half-maximal inhibitory concentration: 34700 nM
For compound 3 the middle estimate is 1.7-fold (0.24 log units) below the measured one; the range from low to high includes it.
By their numbers in this assay, from the lowest: compounds 1, 3 and 2 (each within the scatter of the next).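

In this assay, within the data shown here, putting 3-nitrophenyl in place of 2-carboxyethyl on a carbonyl carbon gives a 1.2-fold higher number from compound 1 to compound 3 (0.09 log units; within the scatter) as the first step that can be read for a single change. The number therefore does not clearly respond to a sizeable swap, in which an open chain carrying a hydrogen-bond donor gives way to an aromatic ring with no such donor. No supporting measurement bears on what lies behind this result.

Among these compounds, with only this one step, it remains open whether the number at this place can be moved at all. A basic amine on the chain, a longer chain ending in a carboxylic acid, or a plain phenyl ring without the nitro group could each test that, as could an amide linkage in place of the ester.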